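This account rests on a few compounds, and the source may have more. Where it says the series, first, only, none or still open, it means among the compounds named here.

Of the compounds shown here, three sharing one core have been measured in a functional assay on A549 cells (Homo sapiens), read by sulforhodamine B assay, with a stated time of 5 days; on this read-out lower numbers stand for stronger inhibition of growth and higher numbers for weaker inhibition of growth. In it, compound 1 `OC[C@H]1O[C@@H](n2cc(F)c3c(-c4ccco4)ncnc32)[C@H](O)[C@@H]1O`, which carries furan-2-yl, gives 110 nM. Compound 2 `OC[C@H]1O[C@@H](n2cc(F)c3c(-c4nccs4)ncnc32)[C@H](O)[C@@H]1O`, which carries 1,3-thiazol-2-yl, gives 900 nM, and compound 3 `OC[C@H]1O[C@@H](n2cc(F)c3c(-c4ccc[nH]4)ncnc32)[C@H](O)[C@@H]1O`, which carries 1H-pyrrol-2-yl, gives 190 nM. Compound 3 thus stands close to one neighbour and apart from the other: the measurements show a 1.7-fold higher number from compound 1 to compound 3 (0.24 log units; within the scatter), but also a 4.7-fold lower number from compound 2 to compound 3 (0.68 log units; beyond the scatter).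

Compound 4 `OC[C@H]1O[C@@H](n2cc(F)c3c(-c4c[nH]cn4)ncnc32)[C@H](O)[C@@H]1O` has not yet been measured. It has 1H-imidazol-4-yl in place of 1H-pyrrol-2-yl on an aromatic carbon, (1H-imidazol-4-yl in place of 1H-pyrrol-2-yl on an aromatic carbon). Among the measured compounds shown here, no measured step makes this exact change. The closest tested relative of the entering group is the 1,3-thiazol-2-yl of compound 2, and the move to that group from furan-2-yl was an 8.2-fold higher number from compound 1 to compound 2 (0.91 log units; beyond the scatter). For the measured compounds named here, that step and the one between compound 2 and compound 3 are the only ones beyond the scatter, and both put compound 2 at the higher number. The entering group keeps the hydrogen-bond donor of 1H-pyrrol-2-yl, so a somewhat smaller step in the same direction is expected in this assay. The expected change is a 2.6-fold higher number from compound 3 to compound 4 (0.42 log units; beyond the scatter). For compound 4 the estimated value is 500 nM, with an expected range of 150 nM to 2000 nM.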

Compound 4, concentration for 50% growth inhibition: > 10000 nM
Compound 4: only a limit was reported; the forecaster's own chance of this, stated with the estimate: 5%; middle value at least 20-fold (1.30 log units) from the limit.
By their numbers in this assay, from the lowest: compounds 1 and 3 (each within the scatter of the next); then compound 2. At a limit, above all of these: compound 4.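

In this assay compound 4 stands only at a limit of the assay, not at a number: the limit of > 10000 nM in this assay, at which 1 of the 4 values shown sits. Among the earlier compounds, this position, an aromatic carbon next to the ring nitrogen, had shown only a modest spread across furan-2-yl, 1,3-thiazol-2-yl and 1H-pyrrol-2-yl, whereas 1H-imidazol-4-yl opens much larger steps: an at least 52-fold higher number from compound 3 to compound 4 (1.72 log units; beyond the scatter), an at least 11-fold higher number from compound 2 to compound 4 (1.04 log units; beyond the scatter) and an at least 90-fold higher number from compound 1 to compound 4 (1.95 log units; beyond the scatter). The change from compound 3 keeps the count of heavy atoms and the hydrogen-bond donor and adds a second hetero atom and a hydrogen-bond acceptor, so a ring with a donor at this place is not enough on its own to retain growth inhibition.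

As far as these compounds go, with only a limit for compound 4, the true size of these steps stays unknown, as does whether the loss follows the second ring nitrogen itself or the way the ring is attached. From the compounds shown here alone, how 1H-imidazol-2-yl, 1H-pyrazol-3-yl or a methyl on the ring nitrogen of the 1H-imidazol-4-yl would read at this position remains open.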